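The source may report more compounds than this note shows. Statements on the series, on what has been measured and on what is new or still open speak of the compounds shown alone.

Three ureas sharing one core have been examined in an assay on isolated protein for inhibition of acyl-CoA:cholesterol acyltransferase (Oryctolagus cuniculus); on this read-out higher numbers stand for weaker inhibition and lower numbers for stronger inhibition. Compound 2 `CCCCCCc1ccc(NC(=O)Nc2c(C(C)C)cccc2C(C)C)cc1` gives 26 nM, compound 1 `CCCCCCCCCCCCCCc1ccc(NC(=O)Nc2c(C(C)C)cccc2C(C)C)cc1` gives 500 nM, and compound 3 `Cc1ccc(NC(=O)Nc2c(C(C)C)cccc2C(C)C)cc1` gives 250 nM. Between compound 2 and compound 3 the change is hydrogen in place of pentyl on a saturated chain carbon bound to an aromatic carbon, and the resulting step is a 9.6-fold higher number from compound 2 to compound 3 (0.98 log units; beyond the scatter). Between compound 2 and compound 1 the change is octyl in place of hydrogen on a saturated chain carbon, six bonds along the chain from an aromatic carbon, and it gives a 19-fold higher number from compound 2 to compound 1 (1.28 log units; beyond the scatter), so the longer chain here coincides with weaker inhibition.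

Compound 4 `CCCCCCCCCc1ccc(NC(=O)Nc2c(C(C)C)cccc2C(C)C)cc1` has not yet been tested. Compared with compound 3 it carries octyl in place of hydrogen on a saturated chain carbon bound to an aromatic carbon. Within the data shown here, this is the same kind of change as the one from compound 2 to compound 1, but not the same: there the entering octyl sits on a saturated chain carbon six bonds along the chain from an aromatic carbon, here it sits on a saturated chain carbon bound to an aromatic carbon. Since compound 3 gives 250 nM and compound 2 gives 26 nM, while compound 1 gives 500 nM, the nonyl chain of compound 4 is expected to land between those outcomes. The step from compound 3 to compound 4 is therefore expected to be a 4.2-fold lower number from compound 3 to compound 4 (0.62 log units; beyond the scatter) in this assay. Compound 4 is estimated at 60 nM, likely between 20 nM and 200 nM.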

Compound 4, half-maximal inhibitory concentration: 9 nM
The estimate for compound 4 lay 6.7-fold (0.82 log units) above the measured number; the whole stated range lies above it.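

In this assay, octyl in place of hydrogen gives a 28-fold lower number from compound 3 to compound 4 (1.44 log units; beyond the scatter), so this change does not carry from one core to another with the same direction or size, as the earlier step on a longer chain shows: the same change on two cores in this assay, a 19-fold higher number (1.28 log units; beyond the scatter) from compound 2 to compound 1 and a 28-fold lower number (1.44 log units; beyond the scatter) from compound 3 to compound 4, 530-fold (2.73 log units) apart, beyond the scatter of two such steps The replacement of pentyl by hydrogen also changes direction with the starting chain, giving a 56-fold lower number from compound 1 to compound 4 (1.74 log units; beyond the scatter) at the long end of the series: the same change on two cores in this assay, a 9.6-fold higher number (0.98 log units; beyond the scatter) from compound 2 to compound 3 and a 56-fold lower number (1.74 log units; beyond the scatter) from compound 1 to compound 4, 530-fold (2.73 log units) apart, beyond the scatter of two such steps With a 2.9-fold lower number from compound 2 to compound 4 (0.46 log units; beyond the scatter), compound 4 is the strongest of the four, so the result of adding or removing chain carbons depends on the chain already present, though these compounds do not show why, nor do they fix the exact chain length at which inhibition turns weaker.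

A decyl or dodecyl chain on the shared core would show how sharply inhibition falls off beyond the nonyl chain of compound 4. From the compounds shown here alone, whether a chain ending in a carboxylic acid or an amine would follow the same course also remains open.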